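Amine head-group swap on the four-carbon chain

A few compounds are considered here, and "the series" means these few. Any claim that something is new, unique, unknown or untested is made for them only; others in the source may bear on it.

Measured compounds:
compound 1 `CCN(CC)CCCOc1c(OCc2ccccc2)cc(O)c2c(=O)cc(-c3ccccc3)oc12` — 3010 nM
compound 2 `CCN(CC)CCCCOc1c(OCc2ccccc2)cc(O)c2c(=O)cc(-c3ccccc3)oc12` — 1650 nM
compound 3 `O=c1cc(-c2ccccc2)oc2c(OCCCCN3CCCC3)c(OCc3ccccc3)cc(O)c12` — 4660 nM

In a functional assay on HepG2 cells (Homo sapiens) for cytotoxicity, read by MTT assay, with a stated time of 72 h (on this read-out higher numbers stand for weaker inhibition and lower numbers for stronger inhibition), compound 3 gives the highest number of the three. Its nearest neighbour is compound 1, a 1.5-fold higher number from compound 1 to compound 3 (0.19 log units; within the scatter), which keeps the two within the scatter of each other. Against compound 2 the gap is wider, a 2.8-fold higher number from compound 2 to compound 3 (0.45 log units; beyond the scatter), a modest step beyond the scatter.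

Compound 4 `CN1CCN(CCCCOc2c(OCc3ccccc3)cc(O)c3c(=O)cc(-c4ccccc4)oc23)CC1` is not yet measured. It differs from compound 3 in the amine head only: 4-methylpiperazin-1-yl in place of pyrrolidin-1-yl on a saturated chain carbon, four bonds along the chain from an oxygen on an aromatic ring.

Of the measured steps, only one bears on the same position with the chain length of compound 3 and compound 4: a 2.8-fold higher number from compound 2 to compound 3 (0.45 log units; beyond the scatter), an exchange of one amine for another on the four-bond chain, which moved the number modestly. The one-bond-shorter analogues show a 1.5-fold higher number from compound 1 to compound 3 (0.19 log units; within the scatter), within the scatter. Among the measured compounds shown here, no measured pair shows the 4-methylpiperazin-1-yl head itself, so its effect is unknown here. The exchange of amine heads that is measured gave at most a modest step, so for compound 4 a step no larger than that is expected in this assay, in either direction, and most likely none beyond the scatter: a 1.1-fold higher number from compound 3 to compound 4 (0.03 log units; within the scatter).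

Compound 4 is therefore estimated at 5000 nM, with a range from 2000 nM to 12500 nM.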

Compound 4, half-maximal inhibitory concentration: 1500 nM
For compound 4 the middle estimate is 3.3-fold (0.52 log units) above the measured one; measured number outside the range, below it.
By their numbers in this assay, from the lowest: compounds 4, 2, 1 and 3 (each within the scatter of the next, the first and the last beyond it).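

In this assay, the exchange of pyrrolidin-1-yl for 4-methylpiperazin-1-yl, four bonds along the chain from an oxygen on an aromatic ring, gives a 3.1-fold lower number from compound 3 to compound 4 (0.49 log units; beyond the scatter), which runs the opposite way to the earlier amine exchange, a 2.8-fold higher number from compound 2 to compound 3 (0.45 log units; beyond the scatter). The 4-methylpiperazin-1-yl head sits level with the open-chain diethylamino head, at a 1.1-fold lower number from compound 2 to compound 4 (0.04 log units; within the scatter), and the comparison with the shorter-chain diethylamino analogue also stays level, at a 2.0-fold lower number from compound 1 to compound 4 (0.30 log units; within the scatter), so among the three heads on this chain only pyrrolidin-1-yl stands apart, and a ring in the head does not by itself set the number, as compound 3 and compound 4 both carry one. Nothing available accounts for the difference between these two ring heads.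

On these data alone, it remains open whether the second ring nitrogen or its methyl group carries the step, which piperazin-1-yl, piperidin-1-yl and morpholin-4-yl heads on the same chain could separate. Also open, as far as these compounds go, is how the 4-methylpiperazin-1-yl head behaves on a 3-(4-methylpiperazin-1-yl)propyl chain or on a longer chain.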